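This account rests on a few compounds, and the source may have more. Where it says the series, first, only, none or still open, it means among the compounds named here.

Compound 1, `Cc1ccc(OCc2cn(Cc3cccc(Cl)c3)nn2)cc1`, is the starting point of this small series. In a physicochemical assay, read by spectrophotometry, with a stated time of 30 min (a lower number here means a stronger inhibitor, a higher number a weaker inhibitor), compound 1 gives 16.3 ug/mL. Compound 2, `Cc1ccc(OCc2cn(Cc3ccc(Br)cc3)nn2)cc1`, carries 4-bromophenyl in place of 3-chlorophenyl on a saturated chain carbon bound to an aromatic nitrogen and in this assay compound 2 gives 16.3 ug/mL; the step is no change at the digits printed from compound 1 to compound 2 (within the scatter). Compound 3, `Clc1ccc(OCc2cn(Cc3cccc(Cl)c3)nn2)cc1`, keeps the same aryl group on the triazole side as compound 1 but differs in its core, the counted difference being (chloro in place of methyl on an aromatic carbon). In this assay compound 3 gives 23.3 ug/mL, and the step from the core of compound 1 to the core of compound 3 is a 1.4-fold higher number from compound 1 to compound 3 (0.16 log units; within the scatter). Among the three measured compounds, then, every step falls within the usual scatter, and none of them can be set apart from the others.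

Compound 4, `Clc1ccc(OCc2cn(Cc3ccc(Br)cc3)nn2)cc1`, has not yet been measured. It stands to compound 3 exactly as compound 2 stands to compound 1: the difference is 4-bromophenyl in place of 3-chlorophenyl on a saturated chain carbon bound to an aromatic nitrogen, with the same place word for word, so it is the same change made on the other core. Because the earlier instance of this change gave no change at the digits printed from compound 1 to compound 2 (within the scatter), compound 4 is expected to sit close to compound 3, and the expected step is a 1.0-fold lower number from compound 3 to compound 4 (0.01 log units; within the scatter). This expectation rests on a single prior example and on two cores whose own difference, (chloro in place of methyl on an aromatic carbon), also produced a step within the scatter. For compound 4 in this assay the estimated value is 23 ug/mL, expected to fall between 14 ug/mL and 38 ug/mL.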

Compound 4, half-maximal inhibitory concentration: 11 ug/mL
Compound 4: the middle estimate sits 2.1-fold (0.32 log units) above what was measured; measured number below the stated range.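

In this assay, the change from 3-chlorophenyl to 4-bromophenyl on a saturated chain carbon bound to an aromatic nitrogen gives no change at the digits printed from compound 1 to compound 2 (within the scatter) on the core of compound 1, but a 2.1-fold lower number from compound 3 to compound 4 (0.33 log units; beyond the scatter) on the core of compound 3, so the result of this change did not carry over unchanged from one core to the other, although the second step is only modest. Chloro in place of methyl on an aromatic carbon gives a 1.4-fold higher number from compound 1 to compound 3 (0.16 log units; within the scatter) with the 3-chlorophenyl group and a 1.5-fold lower number from compound 2 to compound 4 (0.17 log units; within the scatter) with the 4-bromophenyl group, so neither of these pairs separates the two cores beyond the scatter. The comparison rests on one pair for each core and sets no rule for any other core, and nothing shown here accounts for the difference between the two pairs.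

The compounds shown leave open how the same change behaves on a core carrying a methoxy group or a carboxylic acid in place of the methyl or chloro. They also leave open whether an amine on the aromatic ring, or a longer chain in place of the saturated chain carbon, would give a step of similar size.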